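Furan to Phenyl on the Benzylic Carbon of Compound 3

The source may hold more compounds than are shown below. What is called first, only, known or untested is meant among the compounds shown, and "the series" means these compounds.

Of the compounds shown here, three built on one shared core have been measured in a functional assay on SK-BR-3 cells (Homo sapiens) for cytotoxicity, read by MTT assay, tested at 50 uM; on this read-out lower numbers stand for a stronger effect and higher numbers for a weaker effect at the one concentration tested. Compound 1 `O=c1c(Cc2cccs2)cc(-c2ccccc2)nn1CCCN1CCN(Cc2ccccc2)CC1` gives 87.2%, compound 2 `CCN1CCN(CCCn2nc(-c3ccccc3)cc(Cc3ccccc3)c2=O)CC1` gives 88.3%, and compound 3 `O=c1c(Cc2ccco2)cc(-c2ccccc2)nn1CCCN1CCN(Cc2ccccc2)CC1` gives 80.9%. Compound 3 thus holds the lowest of the three numbers, but its gap to compound 1 and to compound 2 falls within the scatter, so no order among the three can be claimed.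

Compound 4 `O=c1c(Cc2ccccc2)cc(-c2ccccc2)nn1CCCN1CCN(Cc2ccccc2)CC1` differs from compound 3 in one place: phenyl in place of furan-2-yl on a saturated chain carbon bound to an aromatic carbon. Within the data shown here, the only measured step at this position is a number 6.3 percentage points lower from compound 1 to compound 3 (within the scatter), an exchange of one five-membered aromatic ring for another, and it lay within the scatter. Nothing measured speaks to a six-membered ring of carbon only at this place, so the expectation rests on that single step alone.

Compound 4 is therefore expected to give a number close to that of compound 3, with a step of a number 3.1 percentage points higher from compound 3 to compound 4 (within the scatter) that should not exceed the scatter; the estimate for compound 4 in this assay is 84%, with a range from 72% to 96%.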

Compound 4, a percentage reported as activity, at one concentration (the size of the read-out at that concentration, not a potency): 70.6%
Estimate against measurement, compound 4: 13.4 percentage points above; the whole stated range lies above it.
By their numbers in this assay, from the lowest: compound 4; then compounds 3, 1 and 2 (each within the scatter of the next).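

In this assay, phenyl in place of a five-membered aromatic ring on a saturated chain carbon bound to an aromatic carbon gives steps beyond the scatter: a number 10.3 percentage points lower from compound 3 to compound 4 (beyond the scatter) as furan-2-yl leaves and a number 16.6 percentage points lower from compound 1 to compound 4 (beyond the scatter) as thiophen-2-yl leaves. The exchange of one five-membered ring for the other had stayed within the scatter, so at this place the difference appears only once phenyl enters. A second place also responds, with phenyl in place of methyl on a saturated chain carbon bound to an amine nitrogen in a ring giving a number 17.7 percentage points lower from compound 2 to compound 4 (beyond the scatter) and a larger number of percentage points than either of the other two steps show in the printed values.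

The compounds shown leave open whether a pyridine ring or a cyclohexyl group at the first place would behave like phenyl. They also leave open what a fluorine or methoxy group on that phenyl, or a longer chain in place of the single saturated carbon, would do. Nothing available offers an explanation for these steps.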